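Removing a Chloro Group: What Earlier Data Suggest

The compounds below may be only part of what the source reports. "The series", "measured", "known", "first", "only" and "open" are said of these compounds alone.

Of the compounds shown here, three have so far been tested in an ADME assay on HCT-116 cells (Homo sapiens) for cytotoxicity, read by MTT assay, with a stated time of 48 h, tested at 0.2 uM; on this read-out higher numbers stand for a stronger effect at the one concentration tested and lower numbers for a weaker effect. Compound 1, `O=C1C(=O)N(CC(CO)NCCCNc2ccnc3cc(Cl)ccc23)c2ccccc21`, gives 2% in this assay. Compound 2, `O=C1C(=O)N(CC(CO)NCCCNc2ccnc3cc(Cl)ccc23)c2ccc(Cl)cc21`, gives 0%. Compound 3, `O=C1C(=O)N(CC(CO)NCCNc2ccnc3cc(Cl)ccc23)c2ccc(Cl)cc21`, gives 0%. Compounds 2 and 1 differ in a single place: hydrogen in place of chloro on an aromatic carbon. This change made a step of a number 2 percentage points higher from compound 2 to compound 1 (within the scatter), so the two values sit level with each other. Compound 3 and compound 2 differ in a larger way; the difference between the two cores is not broken down here. Their readings agree at the digits reported, and compound 3 is also within the scatter of compound 1.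

Compound 4, `O=C1C(=O)N(CC(CO)NCCNc2ccnc3cc(Cl)ccc23)c2ccccc21`, has not yet been measured in this assay. It stands to compound 3 exactly as compound 1 stands to compound 2: hydrogen in place of chloro on an aromatic carbon, at a place described in the very same words, so this is the same change made a second time. Because the earlier step of a number 2 percentage points higher from compound 2 to compound 1 (within the scatter) stayed within the scatter, the step from compound 3 to compound 4 is expected to be small as well, estimated as a number 1 percentage points higher from compound 3 to compound 4 (within the scatter). Compound 4 is therefore expected to give about 1% in this assay, with a likely range from 0% to 10%.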

Compound 4, a percentage reported as inhibition, at one concentration (the size of the read-out at that concentration, not a potency): 0%
The estimate for compound 4 lay 1 percentage points above the measured number; the range from low to high includes it.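

In this assay, putting hydrogen in place of chloro on an aromatic carbon gives no change at the digits printed from compound 3 to compound 4 (within the scatter). Set beside the earlier case, the same change behaves alike on the two cores, with no gap that stands out from the usual spread of such measurements: the same change on two cores in this assay, a number 2 percentage points higher (within the scatter) from compound 2 to compound 1 and no change at the digits printed (within the scatter) from compound 3 to compound 4, 2 percentage points apart, within the scatter of two such steps. This shows that, on these two cores and at this single concentration, removing the chloro group leaves the reading where it was, but every reading here is small, so a change that makes no visible difference may simply have little effect left to alter, and the result says nothing about potency, about other concentrations, or about a core on which the effect is large.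

The compounds shown leave open how a different group would read in the same place, since only chloro and hydrogen appear there, and a fluoro group, a methoxy group or a nitrile could be compared directly with them. They also leave open whether a longer chain between the two amine nitrogens, or a carboxylic acid in place of the hydroxyl group, would give a reading large enough for such a comparison to mean more.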